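This account rests on a few compounds, and the source may have more. Where it says the series, first, only, none or still open, it means among the compounds named here.

Three compounds sharing the same core have been examined in an ADME assay for solubility; on this read-out lower numbers stand for lower solubility and higher numbers for higher solubility. Compound 1 `Cc1c(O)c(=O)ccn1CCCc1cc(C(C)(C)C)c(O)c(C(C)(C)C)c1` gives a limit in this assay, < 100 ug/mL. Compound 2 `Cc1c(C)c2c(c(C)c1O)CCC(C)(CNCCCCn1ccc(=O)c(O)c1C)O2` likewise gives a limit, < 100 ug/mL. Compound 3 `Cc1c(C)c2c(c(C)c1OC(=O)c1ccc(N)cc1)CC(CCn1ccc(=O)c(O)c1C)O2` also gives a limit, < 100 ug/mL. Compound 3 therefore stands where every measured value of the set stands, namely at the limit of < 100 ug/mL in this assay, at which 3 of the 3 values shown sit, and nothing in the numbers sets any one of the three apart from the others.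

Compound 4 `Cc1c(C)c2c(c(C)c1OC(=O)CCCN)CC(CCn1ccc(=O)c(O)c1C)O2` differs from compound 3 in a single place: 3-aminopropyl in place of 4-aminophenyl on a carbonyl carbon. Among the measured compounds shown here, no two measured compounds differ by one change, so there is no measured step against which this one can be compared, and the three limits give no direction of their own.

The step is expected to be a step that the limit leaves unreadable from compound 3 to compound 4, which would lie within the usual scatter rather than beyond it. Compound 4 is accordingly estimated at 60 ug/mL, with a plausible span from 15 ug/mL to 250 ug/mL.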

Compound 4, solubility: 10000 ug/mL
For compound 4 the middle estimate is 170-fold (2.22 log units) below the measured one; measured number outside the range, above it.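

In this assay, this carbonyl carbon proves to be a place where a single exchange can matter greatly: 3-aminopropyl in place of 4-aminophenyl gives an at least 100-fold higher number from compound 3 to compound 4 (2.00 log units; beyond the scatter). As far as these compounds go, compound 3 gives < 100 ug/mL, which is a limit and not a number, so the full size of the step remains unknown. Compound 4 is the only compound shown that stands clear of the level shared by the others: the limit of < 100 ug/mL in this assay, at which 3 of the 4 values shown sit.

Still open, from the compounds shown here alone, is whether the departure of the aromatic ring alone carries this step, or whether the amine at the end of the new chain also takes part. A plain propyl group or a longer chain ending in an amine on the same carbonyl carbon would help separate these two readings.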